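Pyrimidinyl for chloropyridinyl on the oxime of the series

A few compounds are considered here, and "the series" means these few. Any claim that something is new, unique, unknown or untested is made for them only; others in the source may bear on it.

Compound 1 `O=C(CCCN1CCCN(c2ccc(Cl)cn2)CC1)c1ccc(F)cc1` and compound 2 `O=C(CCCN1CCCN(c2ncccn2)CC1)c1ccc(F)cc1` share the ketone core and differ only in the aryl group on the ring amine nitrogen. In an assay on cells with Sigma non-opioid intracellular receptor 1 (Homo sapiens) as the target (a lower number here means a stronger inhibitor, a higher number a weaker inhibitor), compound 1 gives 30 nM; 30.2 nM (2 entries) and compound 2 gives 63 nM; 63.1 nM (2 entries); each rests on repeated entries (the several entries of compound 1 in this assay, 30 nM; 30.2 nM (2 entries) and (the several entries of compound 2 in this assay, 63 nM; 63.1 nM (2 entries))). Compound 3 `O/N=C(/CCCN1CCCN(c2ccc(Cl)cn2)CC1)c1ccc(F)cc1` carries the oxime in place of the carbonyl, and in this assay compound 3 gives 113 nM; this is the only number shown for compound 3, two further entries carrying no single number.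

Compound 4 `O/N=C(/CCCN1CCCN(c2ncccn2)CC1)c1ccc(F)cc1` is the unmeasured oxime partner. The change from compound 3 to compound 4 is pyrimidin-2-yl in place of 5-chloropyridin-2-yl on an amine nitrogen in a ring. The same exchange is seen between compound 1 and compound 2 on the ketone core, where the two values sit close together. Applying that exchange to the oxime, the step from compound 3 to compound 4 is expected to be small and toward weaker binding, a 2.0-fold higher number from compound 3 to compound 4 (0.31 log units; beyond the scatter), near the edge of the scatter. Compound 4 is therefore estimated at 230 nM in this assay, with a range from 100 nM to 520 nM.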

Compound 4, inhibition constant: 148 nM
The estimate for compound 4 lay 1.6-fold (0.19 log units) above the measured number; the measured number falls inside the stated range.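

In this assay, the exchange of 5-chloropyridin-2-yl for pyrimidin-2-yl on the amine nitrogen in the ring now has a reading on the oxime, a 1.3-fold higher number from compound 3 to compound 4 (0.12 log units; within the scatter). This step lies within the scatter, so the two oxime compounds cannot be told apart, and on the oxime either group on this nitrogen gives the same reading in this assay. The ketone pair could not show this: compound 1 gives 30 nM; 30.2 nM (2 entries) and compound 2 gives 63 nM; 63.1 nM (2 entries), values that say nothing about the oxime by themselves.

Open, on these data alone, is whether other groups on this nitrogen, such as unsubstituted phenyl or 5-fluoropyridin-2-yl, stay in the same range on the oxime. Also open, as far as these compounds go, is how a longer chain on the ring nitrogen reads in this assay.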